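A few compounds are considered here, and "the series" means these few. Any claim that something is new, unique, unknown or untested is made for them only; others in the source may bear on it.

Compound 1 `O=C(NO)c1cccc(S(=O)(=O)N[C@H](C(=O)Nc2ccccc2)c2ccccc2)c1` and compound 2 `O=C(NO)c1cccc(S(=O)(=O)NCc2ccccc2)c1` share one core and differ only at the saturated chain carbon bound to an aromatic carbon and a sulfonamide nitrogen, where compound 1 bears a phenylcarbamoyl and compound 2 a hydrogen. Going by the values given here, in an assay on isolated protein for inhibition of histone deacetylase 8 (Homo sapiens), read by fluorescence, with stated times of 5 min and 30 min (a lower number here means a stronger inhibitor, a higher number a weaker inhibitor), compound 1 gives 910 nM, while compound 2 gives 80 nM, the lowest number of the two measured so far, with compound 1 as its only neighbour. That exchange gave an 11-fold lower number from compound 1 to compound 2 (1.06 log units; beyond the scatter). Compound 3 `O=C(NO)c1cccc(S(=O)(=O)N[C@H](C(=O)NCc2ccccc2)c2ccccc2)c1` introduces (benzylcarbamoyl in place of hydrogen on a saturated chain carbon bound to an aromatic carbon and a sulfonamide nitrogen). Among the compounds with values here, the only step that bears on this change is the large one between compound 1 and compound 2, and it ran the other way: removing a carbamoyl substituent from that carbon lowered the number sharply. Restoring a related substituent is therefore expected to raise the number in this assay by a comparable, perhaps slightly smaller, amount, a 6.3-fold higher number from compound 2 to compound 3 (0.80 log units; beyond the scatter). Compound 3 is accordingly estimated at 500 nM, within a range from 150 nM to 1600 nM.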

Compound 3, half-maximal inhibitory concentration: 9200 nM
Estimate against measurement, compound 3: 18-fold (1.26 log units) below; measured number above the stated range.
By their numbers in this assay, from the lowest: compound 2; then compound 1; then compound 3.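

In this assay, benzylcarbamoyl on the saturated chain carbon bound to an aromatic carbon and a sulfonamide nitrogen gives a 120-fold higher number from compound 2 to compound 3 (2.06 log units; beyond the scatter) and so costs far more than phenylcarbamoyl did at the same carbon. The loss at this carbon therefore does not depend on the carbamoyl alone, since the group on the amide-type nitrogen also counts: benzyl in place of phenyl gives a 10-fold higher number from compound 1 to compound 3 (1.00 log units; beyond the scatter) in the same assay. No measurement offered here accounts for either step.

From the compounds shown here alone, whether any substituent at this carbon can match the hydrogen of compound 2 stays open, as does the effect of a longer chain on the amide nitrogen, or of a carboxylic acid or an amine in place of the carbamoyl. Going by these compounds, compound 1 and compound 3 share one configuration at this carbon, and what the opposite configuration would give also stays open.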